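A few compounds are considered here, and "the series" means these few. Any claim that something is new, unique, unknown or untested is made for them only; others in the source may bear on it.

Series notes. The shared core of compound 1 `c1ccc(-c2ccnc3c2c(-c2ccccc2)nn3-c2ccccc2)cc1` carries an unsubstituted phenyl at the position varied here. In a functional assay on HepG2 cells (Homo sapiens) for inhibition, read by MTT assay, with a stated time of 48 h (on this read-out higher numbers stand for weaker inhibition and lower numbers for stronger inhibition), compound 1 gives 3210 nM. Compound 2 `Brc1ccc(-c2ccnc3c2c(-c2ccccc2)nn3-c2ccccc2)cc1` differs from it by bromo in place of hydrogen on an aromatic carbon; in this assay compound 2 gives 49900 nM, the highest of the three numbers in hand. Compound 3 `COc1ccc(-c2nc3c(c(-c4ccccc4)nn3-c3ccccc3)c(-c3ccc(N4CCCCC4)cc3)c2C#N)cc1`, built on a more heavily substituted version of the core, gives 12500 nM in this assay. Going by the values given here, the one measured step that touches the varied position is a 16-fold higher number from compound 1 to compound 2 (1.19 log units; beyond the scatter).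

Compound 4 `Cc1ccc(-c2ccnc3c2c(-c2ccccc2)nn3-c2ccccc2)cc1` is not yet measured. Its difference from compound 2: methyl in place of bromo on an aromatic carbon. Among the compounds with values here, the only step bearing on it is a 16-fold higher number from compound 1 to compound 2 (1.19 log units; beyond the scatter), so the bromo case reads clearly worse than the hydrogen case. Within the data shown here, no measured compound carries methyl at this carbon, so the methyl case is bracketed only by the values of compound 1 and compound 2. Compound 4 is therefore expected to fall between the two, a step of a 3.3-fold lower number from compound 2 to compound 4 (0.52 log units; beyond the scatter). Compound 4 is estimated at 15000 nM in this assay, with a range from 5000 nM to 45000 nM.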

Compound 4, half-maximal inhibitory concentration: 10700 nM
The estimate for compound 4 lay 1.4-fold (0.15 log units) above the measured number; the range from low to high includes it.
By their numbers in this assay, from the lowest: compound 1; then compounds 4 and 3 (each within the scatter of the next); then compound 2.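

In this assay, a second group at this carbon shows that the penalty seen with bromo is not the same for every substituent: methyl in place of hydrogen gives a 3.3-fold higher number from compound 1 to compound 4 (0.52 log units; beyond the scatter) and methyl in place of bromo gives a 4.7-fold lower number from compound 2 to compound 4 (0.67 log units; beyond the scatter) so the two substituents are separated beyond the scatter. Among the three compounds that differ only here, the numbers rise from hydrogen to methyl to bromo, and compound 1 keeps the lowest number of the three. Nothing in hand accounts for this order.

From the compounds shown here alone, whether any group at this carbon can bring the number below that of compound 1 remains open. An amine, a carboxylic acid or a fluoro group here could test whether the order among these three compounds extends further.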